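The source may report more compounds than this note shows. Statements on the series, on what has been measured and on what is new or still open speak of the compounds shown alone.

Working notes on the series.

Compound 1 `CCCCCCCCc1ccc(OCC(=O)Cn2nnc(-c3cccnc3)n2)cc1` and compound 2 `CCCCCCCCc1ccc(OCC(=O)Cn2nnc(C(=O)OC)n2)cc1` share one core and differ only at the substituent on the five-membered aromatic ring with four nitrogen atoms. In an assay on microsomes from brain for inhibition of Fatty-acid amide hydrolase 1 (Rattus norvegicus), read by fluorescence and HPLC, with a stated time of 60 min (a lower number here means a stronger inhibitor, a higher number a weaker inhibitor), compound 1 gives 23 nM, and compound 2 gives 88 nM. For the measured compounds named here, the single step so far, a 3.8-fold higher number from compound 1 to compound 2 (0.58 log units; beyond the scatter), is the only measured change at this position. Going by the values given here, compound 2 therefore stands as the higher of the two numbers measured, with compound 1 as its only neighbour.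

Compound 3 `CCCCCCCCc1ccc(OCC(=O)Cn2nnc(CCC(=O)O)n2)cc1` is the next member and has not been measured. Relative to compound 2 the change is 2-carboxyethyl in place of methoxycarbonyl on an aromatic carbon; the place of the change is the same aromatic carbon that carried methoxycarbonyl in compound 2 and pyridin-3-yl in compound 1.

Among the compounds with values here, only one step bears on this change, the one from pyridin-3-yl to methoxycarbonyl, which was modest. Within the data shown here, no measured step covers a 2-carboxyethyl group or any other acid at this position, so the direction of the new step rests on a single precedent and is uncertain. The expectation for compound 3 in this assay is a step of a 1.8-fold higher number from compound 2 to compound 3 (0.26 log units; within the scatter), with a weaker number more likely than a stronger one. The estimate for compound 3 is 160 nM, within a range from 40 nM to 650 nM.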

Compound 3, half-maximal inhibitory concentration: 30 nM
Beside the measured number, compound 3's estimate is 5.3-fold (0.73 log units) above it; the measured number lies below the stated range.
By their numbers in this assay, from the lowest: compounds 1 and 3 (each within the scatter of the next); then compound 2.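

Replacing methoxycarbonyl with 2-carboxyethyl on this aromatic carbon gives a 2.9-fold lower number from compound 2 to compound 3 (0.47 log units; beyond the scatter) in this assay, so a free carboxylic acid on a short chain is tolerated here, and the weaker number of compound 2 does not extend to this group. The step of a 1.3-fold higher number from compound 1 to compound 3 (0.12 log units; within the scatter) leaves pyridin-3-yl and 2-carboxyethyl indistinguishable in this assay, although one is an aromatic ring and the other an open chain with no ring, so among these three compounds only the methoxycarbonyl group stands apart, by steps beyond the scatter. Nothing available explains why the ester stands apart from the other two groups.

Still open, as far as these compounds go, is whether the length of the chain or the acid itself sets the number of compound 3: a carboxymethyl group, a 3-carboxypropyl group and the methyl ester of the 2-carboxyethyl chain would separate these two factors. Also open, from the compounds shown here alone, is how an amine or a primary amide on the same chain would compare with the carboxylic acid at this position.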